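This account rests on a few compounds, and the source may have more. Where it says the series, first, only, none or still open, it means among the compounds named here.

Measured compounds:

Compound 1, `Fc1cncc(-n2ncc3cc(F)ccc32)c1`: in an ADME assay on cells for inhibition of cytochrome P450 11B1, mitochondrial (Homo sapiens), read by HTRF, with stated times of 1 h and 3 h (a lower number here means a stronger inhibitor, a higher number a weaker inhibitor), compound 1 gives > 8300 nM, which is a limit of the assay and not a number.
Compound 2, `CC(O)(c1cncc(-n2ncc3cc(F)ccc32)c1)C(F)(F)F`: in this assay compound 2 gives 47 nM.
Compound 3, `CC(C)(O)c1cncc(-n2ncc3ccccc32)c1`: in this assay compound 3 gives 535 nM.

Of the two real numbers shown, compound 3 has the higher one, meaning it is the weaker inhibitor of the two; compound 2 has the lower one, and the gap between them is beyond the usual scatter. The third value sits at the limit (the limit of > 8300 nM in this assay, at which 1 of the 3 values shown sits). Among the measured compounds shown here, the only step measured between two compounds that differ in one place is an at least 170-fold lower number from compound 1 to compound 2 (2.24 log units; beyond the scatter), and that step concerns a different change from the one taken here.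

Compound 4, `Cc1nn(-c2cncc(C(C)(C)O)c2)c2ccccc12`, is the next compound to be measured. It differs from compound 3 by methyl in place of hydrogen on an aromatic carbon. For the measured compounds named here, no measured step speaks to this particular change, so there is no basis for expecting a shift in either direction. The expected step is therefore no change at the digits printed from compound 3 to compound 4 (within the scatter), within the scatter. In this assay compound 4 is estimated at 535 nM, with a range from 150 nM to 2000 nM.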

Compound 4, half-maximal inhibitory concentration: 779 nM
For compound 4 the middle estimate is 1.5-fold (0.16 log units) below the measured one; low and high end bracket the measured number.
By their numbers in this assay, from the lowest: compound 2; then compounds 3 and 4 (each within the scatter of the next). At a limit, above all of these: compound 1.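

In this assay, placing methyl on this aromatic carbon, next to the ring nitrogen, gives a 1.5-fold higher number from compound 3 to compound 4 (0.16 log units; within the scatter), so this position takes a methyl with the two compounds indistinguishable in this measurement. Among the compounds shown here, the earlier compounds all carry hydrogen here, so they could say nothing about this position, and their one large step concerned a different place on the shared core. Nothing measured here explains this outcome.

On these data alone, it remains open whether this position would tolerate a longer chain, such as ethyl or propyl, or a group of another kind, such as an amine or a carboxylic acid. As far as these compounds go, it is also open whether methyl here would give a similar result on the fluorinated core of compound 2, which carries the 1-hydroxy-1-(trifluoromethyl)ethyl group.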